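Alkyl Groups on the Ring Amine Nitrogen of a Shared Core

The source may hold more compounds than are shown below. What is called first, only, known or untested is meant among the compounds shown, and "the series" means these compounds.

Measured so far:
compound 1 `CN1CCN(c2nc3c(S(=O)(=O)c4cccc5ccccc45)cccc3o2)CC1` — 9.7 nM
compound 2 `CCCCN1CCN(c2nc3c(S(=O)(=O)c4cccc5ccccc45)cccc3o2)CC1` — 88 nM
compound 3 `CC(C)CN1CCN(c2nc3c(S(=O)(=O)c4cccc5ccccc45)cccc3o2)CC1` — 176 nM

In an assay on HeLa cells for displacement of a labelled ligand from 5-hydroxytryptamine receptor 6 (Homo sapiens) (on this read-out lower numbers stand for stronger inhibition and higher numbers for weaker inhibition), compound 3 has the highest of the three numbers: an 18-fold higher number from compound 1 to compound 3 (1.26 log units; beyond the scatter) and a 2.0-fold higher number from compound 2 to compound 3 (0.30 log units; within the scatter), the latter within the scatter. Compound 4 `O=S(=O)(c1cccc2ccccc12)c1cccc2oc(N3CCN(C4CCC4)CC3)nc12` differs from compound 3 by cyclobutyl in place of isobutyl on an amine nitrogen in a ring. Within the data shown here, the steps that bear on this are a 9.1-fold higher number from compound 1 to compound 2 (0.96 log units; beyond the scatter) and an 18-fold higher number from compound 1 to compound 3 (1.26 log units; beyond the scatter), both from hydrogen to an alkyl group, while a 2.0-fold higher number from compound 2 to compound 3 (0.30 log units; within the scatter) shows that swapping one such alkyl group for another of like size left the number within the scatter. Exchanging isobutyl for cyclobutyl is therefore expected to give a 1.2-fold lower number from compound 3 to compound 4 (0.07 log units; within the scatter), nothing beyond the scatter. Compound 4 is estimated at 150 nM, between 50 nM and 450 nM.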

Compound 4, inhibition constant: 72 nM
Compound 4: the middle estimate sits 2.1-fold (0.32 log units) above what was measured; measured number inside the range.
By their numbers in this assay, from the lowest: compound 1; then compounds 4, 2 and 3 (each within the scatter of the next, the first and the last beyond it).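

In this assay the ring form of this four-carbon group separates from branched isobutyl (a 2.4-fold lower number from compound 3 to compound 4 (0.39 log units; beyond the scatter)) but not from straight butyl (a 1.2-fold lower number from compound 2 to compound 4 (0.09 log units; within the scatter)), so the shape of the group on this ring nitrogen can shift the number even with the heavy-atom count unchanged. The ring does not recover the methyl result (a 7.4-fold higher number from compound 1 to compound 4 (0.87 log units; beyond the scatter)). No evidence on hand accounts for the difference between cyclobutyl and isobutyl.

Open, from the compounds shown here alone, is where ethyl or cyclopropyl on this nitrogen would fall relative to methyl and cyclobutyl. Also open, going by these compounds, is whether a bare hydrogen there would give a number lower or higher than methyl.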